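From methylamino to anilino, with one measured anchor

This account rests on a few compounds, and the source may have more. Where it says the series, first, only, none or still open, it means among the compounds named here.

Among the measured compounds shown here, compound 1 `CC(C)Nc1nc(NCc2ccco2)c2ccccc2n1` is the only compound here with a number: in an ADME assay on J774.A1 cells (Mus musculus) for inhibition, read by MTT assay, with a stated time of 72 h (on this read-out lower numbers stand for an effect already at smaller amounts and higher numbers for an effect only at larger amounts of compound), compound 1 gives 17000 nM. Compound 2 `CNc1nc(NC(C)C)nc2ccccc12` offers no such anchor. The entry for compound 2 reads "not determined" (no result reported), so it has no place on the scale. Compound 3 `CC(C)Nc1nc(Nc2ccccc2)c2ccccc2n1` has yet to be measured. The structural change leading to it is phenyl in place of methyl on a nitrogen on an aromatic ring, or methylamino to anilino. For the measured compounds named here, no measured step of this kind exists, and its starting point has no number, so the data cannot size the change. The expectation in this assay is therefore cautious: compound 3 should land close to compound 1 at 17000 nM, with no difference beyond the usual scatter and no favoured direction. The estimated value for compound 3 is 15000 nM, with an expected range of 5000 nM to 45000 nM.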

Compound 3, half-maximal effective concentration: 12000 nM
The estimate for compound 3 lay 1.3-fold (0.10 log units) above the measured number; the range from low to high includes it.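

In this assay, this position on a nitrogen on an aromatic ring now has a measured change: phenyl in place of (furan-2-yl)methyl gives a 1.4-fold lower number from compound 1 to compound 3 (0.15 log units; within the scatter), so the two groups cannot be told apart on this read-out. The step from methyl to phenyl, methylamino to anilino, cannot be read, as compound 2 has no number, and the effect of methyl at this place remains unsized. No supporting evidence bears on this result.

The compounds shown leave open whether a group of another kind on this nitrogen, such as a longer alkyl chain or a morpholinylethyl chain, would move the number beyond the scatter. They also leave open whether a carboxylic acid or an amine carried on the phenyl would do so.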